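Swapping one group on compound 3

The source may hold more compounds than are shown below. What is called first, only, known or untested is meant among the compounds shown, and "the series" means these compounds.

Compound 1 `CC(C)c1ccc(OC(Cc2ccc3ccccc3c2)C(=O)O)cc1`: 50 mg/kg
Compound 2 `CCCc1ccc(CC(C)(Oc2ccc(C(C)C)cc2)C(=O)O)cc1`: 0.5 mg/kg
Compound 3 `COc1ccc(Cc2ccc(OC(C)(Cc3ccc(Cl)cc3)C(=O)O)cc2)cc1`: < 10 mg/kg (a limit)

All three values come from a functional assay on the whole organism for inhibition, with Rattus norvegicus as the target; on this read-out lower numbers stand for an effect already at smaller amounts and higher numbers for an effect only at larger amounts of compound. Compound 2 acts at a much smaller dose than compound 1, although the two differ in more than one place. For compound 3 the result is a limit and not a number: < 10 mg/kg. This places compound 3 at a smaller dose than compound 1, but it does not settle where compound 3 stands relative to compound 2.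

Compound 4 `CC(Cc1ccc(Cl)cc1)(Oc1ccc(C2CCSc3ccccc32)cc1)C(=O)O` differs from compound 3 in one group, on an aromatic carbon, para to a large group: a group of 10 heavy atoms (9 carbon, 1 sulfur; one six-membered non-aromatic ring with 1 hetero atom, one six-membered aromatic ring of carbon only) in place of a group of 9 heavy atoms (8 carbon, 1 oxygen; one six-membered aromatic ring of carbon only), on an aromatic carbon. The 4-methoxybenzyl and the group that enters each hold one six-membered aromatic ring of carbon only and carry no net charge, while the entering group also has one six-membered non-aromatic ring with 1 hetero atom.

Among the compounds with values here, no measured pair shows a change of this kind, so there is no firm basis for a direction. In this assay, no step beyond the usual scatter is expected. The estimate means a step that the limit leaves unreadable from compound 3 to compound 4. Compound 4 is expected at 5 mg/kg, with an estimated range from 0.7 mg/kg to 30 mg/kg.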

Compound 4, dose for half-maximal effect: 10 mg/kg
Estimate against measurement, compound 4: 2.0-fold (0.30 log units) below; measured number inside the range.
By their numbers in this assay, from the lowest: compound 2; then compound 4; then compound 1.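

Replacing the 4-methoxybenzyl with the group that holds a sulfur-containing six-membered non-aromatic ring gives, in this assay, a number no lower from compound 3 to compound 4 (the limit leaves the size open). The result shows that this place, an aromatic carbon para to a large group, can carry a group with this extra non-aromatic ring and still give a measurable dose, with compound 4 at 10 mg/kg. Compound 3 has only a limit, < 10 mg/kg, so the size of this step cannot be read, and the evidence for that is the limit itself: the limit of < 10 mg/kg in this assay, at which 1 of the 4 values shown sits.

Going by these compounds, whether this swap changes the dose by a large or a small amount remains open, and so does whether any change would trace to the sulfur atom or to the added ring, since the two enter together in this single swap. Also open, on these data alone, is how a much smaller or differently charged group at this place, such as an ethyl chain or an amine, would compare with the 4-methoxybenzyl and the group in compound 4.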